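Oral exposure in the acrylamide series: piperidinyl analogue

The source may hold more compounds than are shown below. What is called first, only, known or untested is meant among the compounds shown, and "the series" means these compounds.

Measured so far, as maximal plasma concentration in an ADME assay on the whole organism (strain Sprague-Dawley) for pharmacokinetics, with Rattus norvegicus as the target, read by LC-MS, at a dose of 25 mg/kg by the oral route; on this read-out lower numbers stand for lower exposure and higher numbers for higher exposure at the dose given:
Compound 1, `C=CC(=O)N1CC[C@H](N2C(=O)N(c3ccccc3)Cc3cnc(Nc4cccc(N5CCN(C)CC5)c4)nc32)C1`, gives 540 nM.
Compound 2, `C=CC(=O)N1CC[C@H](N2C(=O)N(c3ccccc3)Cc3cnc(Nc4ccc(N5CCN(C)CC5)cc4)nc32)C1`, gives 1450 nM.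
Compound 3, `C=CC(=O)N1CC[C@H](N2C(=O)N(c3ccccc3)Cc3cnc(Nc4ccccc4)nc32)C1`, gives 3800 nM.

Compound 3 stands highest of the three numbers in this assay; compound 2 is nearest, compound 1 furthest, both separated from it by more than the scatter. The two steps that reach compound 3 both remove a 4-methylpiperazin-1-yl from an aromatic carbon: a 7.0-fold higher number from compound 1 to compound 3 (0.85 log units; beyond the scatter) and a 2.6-fold higher number from compound 2 to compound 3 (0.42 log units; beyond the scatter).

Compound 4, `C=CC(=O)N1CC[C@H](N2C(=O)N(c3ccccc3)Cc3cnc(Nc4ccc(C5CCN(C)CC5)cc4)nc32)C1`, is the next step from compound 3: 1-methylpiperidin-4-yl in place of hydrogen on an aromatic carbon. The group enters at the place occupied by 4-methylpiperazin-1-yl in compound 2, so the step from compound 2 to compound 3 bears on it most directly, with the step from compound 1 to compound 3 as a second reference. Both went up when the group was removed; adding a related group is therefore expected to move the number down in this assay by a modest amount, a 2.5-fold lower number from compound 3 to compound 4 (0.40 log units; beyond the scatter). Compound 4 is expected to give about 1500 nM, within 500 nM to 4500 nM.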

Compound 4, maximal plasma concentration: 668 nM
Compound 4: the middle estimate sits 2.2-fold (0.35 log units) above what was measured, within the range that was stated.
By their numbers in this assay, from the lowest: compounds 1 and 4 (each within the scatter of the next); then compound 2; then compound 3.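

In this assay, placing 1-methylpiperidin-4-yl on this aromatic carbon, para to a large group, gives a 5.7-fold lower number from compound 3 to compound 4 (0.76 log units; beyond the scatter) and so lowers the number well beyond the scatter. Exchanging 4-methylpiperazin-1-yl for 1-methylpiperidin-4-yl at the same place gives a 2.2-fold lower number from compound 2 to compound 4 (0.34 log units; beyond the scatter) as a separate step, which shows that the number here depends on which ring is attached and not only on whether a ring is present. No measurement bears on why the two groups differ.

On these data alone, whether a morpholin-4-yl ring or a piperidin-4-yl ring without the methyl group would stay nearer compound 3 remains open. Also open, as far as these compounds go, is whether a small group at this place, such as methoxy or fluorine, would lower the number at all.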